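Bromo to cyano on the hydroxymethyl-bearing core

The source may hold more compounds than are shown below. What is called first, only, known or untested is meant among the compounds shown, and "the series" means these compounds.

Of the compounds shown here, three have been measured in an assay on A10 cells for binding affinity to Endothelin-1 receptor (Rattus norvegicus); on this read-out higher numbers stand for weaker inhibition and lower numbers for stronger inhibition. Compound 1 `N#Cc1ccc(OCc2ccsc2)cc1/C=C(/CCC(=O)O)c1ccccc1` gives 700 nM; compound 2 `N#Cc1ccc(OCc2ccsc2)cc1/C=C(/C(=O)O)c1ccccc1` gives 80 nM; compound 3 `OC/C(=C/c1cc(OCc2ccsc2)ccc1Br)c1ccccc1` gives 2100 nM, the highest of the three, with compound 1 the nearest and compound 2 the furthest. For the measured compounds named here, the one single-point step known so far is an 8.8-fold lower number from compound 1 to compound 2 (0.94 log units; beyond the scatter), which concerns the acid-bearing chain and not the aromatic substituent.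

Compound 4 `N#Cc1ccc(OCc2ccsc2)cc1/C=C(/CO)c1ccccc1` is compound 3 with cyano in place of bromo on an aromatic carbon. Going by the values given here, no measured pair isolates this exchange: compounds 1 and 2 carry the cyano group, but they also carry the acid chain rather than the hydroxymethyl group of compound 3, so their lower numbers cannot be attributed to the cyano group alone. The expectation for compound 4 is therefore a step of a 1.8-fold lower number from compound 3 to compound 4 (0.24 log units; within the scatter) in this assay, with wide uncertainty. For compound 4 the estimated value is 1200 nM, in the range 300 nM to 5000 nM.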

Compound 4, half-maximal inhibitory concentration: 800 nM
The estimate for compound 4 lay 1.5-fold (0.18 log units) above the measured number, within the range that was stated.
By their numbers in this assay, from the lowest: compound 2; then compounds 1 and 4 (each within the scatter of the next); then compound 3.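

In this assay, cyano in place of bromo on the aromatic carbon ortho to a large group and para to a (thiophen-3-yl)methoxy group now has a step of its own, a 2.6-fold lower number from compound 3 to compound 4 (0.42 log units; beyond the scatter), with the hydroxymethyl chain held constant. With cyano fixed, hydroxymethyl in place of carboxy gives a 10-fold higher number from compound 2 to compound 4 (1.00 log units; beyond the scatter), whereas hydroxy in place of carboxymethyl on the saturated chain carbon gives a 1.1-fold higher number from compound 1 to compound 4 (0.06 log units; within the scatter), so the hydroxymethyl and 2-carboxyethyl chains are not told apart on this read-out. No measurement available here accounts for either the aromatic or the chain step.

Open, from the compounds shown here alone, is whether the bromo-to-cyano step carries over to the compounds with a carboxy chain. Also open, going by these compounds, is how a chloro or methoxy group on this aromatic carbon, or a primary amide in place of carboxy, would compare.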